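Swapping 3,4-dichlorophenyl for 4-fluorophenyl: a flat step expected

A few compounds are considered here, and "the series" means these few. Any claim that something is new, unique, unknown or untested is made for them only; others in the source may bear on it.

- Compound 1 (`Nc1nc(N)c2cc(CSC(=S)N3CCN(c4ccccc4)CC3)ccc2n1`) gives 2970 nM
- Compound 2 (`Nc1nc(N)c2cc(CSC(=S)N3CCN(c4ccc(Cl)c(Cl)c4)CC3)ccc2n1`) gives 2940 nM

Both values come from a functional assay on A549 cells (Homo sapiens) for antiproliferative activity, read by MTT assay, with a stated time of 72 h (a higher number here means a weaker inhibitor, a lower number a stronger inhibitor), and stand level with each other. Compound 2 thus has no measured neighbour clearly above or below it. The next compound is compound 3 (`Nc1nc(N)c2cc(CSC(=S)N3CCN(c4ccc(F)cc4)CC3)ccc2n1`), and the change leading to it is 4-fluorophenyl in place of 3,4-dichlorophenyl on an amine nitrogen in a ring in words, 4-fluorophenyl in place of 3,4-dichlorophenyl on an amine nitrogen in a ring. Going by the values given here, only one measured step bears on this, namely a 1.0-fold lower number from compound 1 to compound 2 (0.00 log units; within the scatter) for 3,4-dichlorophenyl in place of phenyl at that same place. Replacing the substituted ring there left the number unmoved, so no step beyond the scatter is expected in this assay in either direction, although one step is thin evidence. The expected step is a 1.0-fold lower number from compound 2 to compound 3 (0.01 log units; within the scatter) and so stays small. For compound 3 the estimated value is 2900 nM with an expected range from 1500 nM to 5500 nM as its bounds.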

Compound 3, half-maximal inhibitory concentration: 2040 nM
Compound 3: middle estimate off by 1.4-fold (0.15 log units), on the high side, within the range that was stated.
By their numbers in this assay, from the lowest: compounds 3, 2 and 1 (each within the scatter of the next).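

In this assay, a second substituted phenyl on the amine nitrogen in a ring again gives no step beyond the scatter: the change brings a 1.4-fold lower number from compound 2 to compound 3 (0.16 log units; within the scatter), and the comparison with the unsubstituted ring gives a 1.5-fold lower number from compound 1 to compound 3 (0.16 log units; within the scatter). Across the three compounds, then, phenyl, 3,4-dichlorophenyl and 4-fluorophenyl cannot be told apart at this position, and the flat result no longer rests on a single pair. No supporting measurement bears on why these steps are so small.

On these data alone, whether this flatness extends beyond phenyl rings stays open, for example with benzyl or acetyl on that nitrogen, or with a methoxy or carboxylic acid group on the ring. The three compounds also share the rest of the structure, so they do not show what a change elsewhere would do.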